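A Silyl Group on a Compound at the Limit

The compounds below may be only part of what the source reports. "The series", "measured", "known", "first", "only" and "open" are said of these compounds alone.

In a functional assay on Malme-3M cells (Homo sapiens) for cytotoxicity, read by MTT assay, with a stated time of 6 days (on this read-out lower numbers stand for an effect already at smaller amounts and higher numbers for an effect only at larger amounts of compound), compound 1 `COC(=O)c1c(-c2ccc([N+](=O)[O-])cc2)oc2cc(OC)ccc2c1=O` gives a measured 1.12 ug/mL. Compound 2 `COc1cc(-c2cc(=O)c3ccc(O)cc3o2)cc(OC)c1OC` reaches only a limit, > 25 ug/mL. Compound 3 `COc1cc(-c2cc(=O)c3ccc(O)c(O)c3o2)cc(OC)c1OC` also reaches only a limit, > 25 ug/mL, and so has no number of its own. Around it stands (the limit of > 25 ug/mL in this assay, at which 2 of the 3 values shown sit). Within the data shown here, the one measured step that bears on compound 3 is a step that the two limits leave unreadable from compound 2 to compound 3. Among the measured compounds shown here, that step gives no size to carry forward, and no measured step covers a change on the oxygen concerned.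

Compound 4 `COc1cc(-c2cc(=O)c3ccc(O)c(O)c3o2)cc(OC)c1O[Si](C)(C)C(C)(C)C` differs from compound 3 in one place: a group of 7 heavy atoms (6 carbon, 1 silicon; no ring) in place of one carbon atom, on an oxygen on an aromatic ring. The data do not fix a direction for this change. Since compound 3 gives only the limit > 25 ug/mL, a reading at that same limit remains a likely outcome for compound 4. The expected step is a number no higher from compound 3 to compound 4 (the limit leaves the size open), with no firm size or direction behind it. Compound 4 is estimated at 25 ug/mL, with an expected range from 8 ug/mL to 60 ug/mL.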

Compound 4, concentration for half-maximal effect: 0.2 ug/mL
For compound 4 the middle estimate is 130-fold (2.10 log units) above the measured one, outside the stated range (below it).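

In this assay, the position that had given no number now gives a clear reading: a group of 7 heavy atoms (6 carbon, 1 silicon; no ring) in place of the methyl on this oxygen produces an at least 120-fold lower number from compound 3 to compound 4 (2.09 log units; beyond the scatter). Among these compounds, the oxygen on an aromatic ring is therefore a place where a change can move the read-out far beyond the usual scatter, which the earlier compounds could not show. The step has only a lower bound, with no upper size, since compound 3 has no number of its own: the limit of > 25 ug/mL in this assay, at which 2 of the 4 values shown sit.

The compounds shown leave open whether the silicon atom is needed, or whether a benzyl group, a hexyl chain or a free hydroxy on this oxygen would give a similar reading. From the compounds shown here alone, the step between the two compounds at the limit cannot be read, so it also remains open whether the added hydroxy on the shared core contributes to this result.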